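Working notes: a methoxy-for-bromo change on a weakly active anilinothiazole

The compounds below may be only part of what the source reports. "The series", "measured", "known", "first", "only" and "open" are said of these compounds alone.

Measured so far in a functional assay on RKO cells (Homo sapiens) for cytotoxicity, read by resazurin assay, with a stated time of 72 h; on this read-out lower numbers stand for stronger inhibition and higher numbers for weaker inhibition:
compound 1 `Cc1nc2ccccc2n1-c1csc(Nc2ccc(Br)cc2)n1`: 60000 nM
compound 2 `c1ccc(Nc2nc(-n3cnc4ccccc43)cs2)cc1`: > 100000 nM
compound 3 `Brc1ccc(Nc2nc(-n3cnc4ccccc43)cs2)cc1`: > 100000 nM

Among the measured compounds shown here, compound 1 gives the only number in this assay, 60000 nM. For compound 2 the read-out is a limit of the assay, > 100000 nM. For compound 3 the read-out is also a limit, > 100000 nM. For the measured compounds named here, compound 1 therefore stands alone as the one compound with a readable value, the other two sitting at the limit of > 100000 nM in this assay, at which 2 of the 3 values shown sit.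

Two single-point steps are known. The step of an at least 1.6-fold higher number from compound 1 to compound 3 (0.22 log units; that floor lies within the scatter), hydrogen in place of methyl on an aromatic carbon, sits at its floor within the scatter. The step that the two limits leave unreadable from compound 2 to compound 3, bromo in place of hydrogen on an aromatic carbon, cannot be read, as both ends are limits.

Compound 4 `COc1ccc(Nc2nc(-n3c(C)nc4ccccc43)cs2)cc1` differs from compound 1 by methoxy in place of bromo on an aromatic carbon. Going by the values given here, no measured step changes the same group, and the one step touching the same position is unreadable, so no direction beyond the scatter can be expected for a 1.3-fold higher number from compound 1 to compound 4 (0.12 log units; within the scatter). Compound 4 is estimated at 80000 nM, between 30000 nM and 250000 nM, with a fair chance that this assay returns only a limit.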

Compound 4, half-maximal inhibitory concentration: 52500 nM
Compound 4: the middle estimate sits 1.5-fold (0.18 log units) above what was measured; the measured number falls inside the stated range.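

In this assay, among the compounds shown here, the change from 4-bromophenyl to 4-methoxyphenyl gives a 1.1-fold lower number from compound 1 to compound 4 (0.06 log units; within the scatter), the first readable step at this position, as the earlier step from hydrogen to bromo there cannot be read. On this read-out bromo and methoxy are therefore not told apart, even though methoxy brings a hydrogen-bond acceptor and bromo brings none. Compound 2 and compound 3 remain limits of the assay and not numbers: the limit of > 100000 nM in this assay, at which 2 of the 4 values shown sit.

As far as these compounds go, whether any other group at this position, such as an amine or a carboxylic acid, would move the number beyond the scatter remains open. For the compounds shown here, also open is whether the methyl on the core matters, as the only step that changes it has a floor within the scatter and no step shows that change with methoxy in place.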